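This account rests on a few compounds, and the source may have more. Where it says the series, first, only, none or still open, it means among the compounds named here.

Compound 3 `Cc1cc(C#N)cc(C)c1Oc1nc(Nc2ccc(C#N)cc2)ncc1-c1cccc2ccccc12` gives only a limit in an ADME assay on MT4 cells (Homo sapiens) for cytotoxicity, read by MTT assay, with a stated time of 5 days (a lower number here means that less compound is tolerated, a higher number that more compound is tolerated), > 267000 nM. Compound 1 `COc1ccc(-c2cnc(Nc3ccc(C#N)cc3)nc2Oc2c(C)cc(C#N)cc2C)cc1` also gives only a limit in this assay, > 279000 nM. Compound 2 `Cc1cc(C)cc(-c2cnc(Nc3ccc(C#N)cc3)nc2Oc2c(C)cc(C#N)cc2C)c1` gives a number in this assay, 39000 nM. Because two of the three values are limits, the step that the two limits leave unreadable from compound 1 to compound 3 cannot be sized, and the step of an at least 6.8-fold higher number from compound 2 to compound 3 (0.83 log units; beyond the scatter) can be read only as a lower bound. Compound 4 `Cc1cc(C#N)cc(C)c1Oc1nc(Nc2ccc(C#N)cc2)ncc1-c1ccc(-c2ccccc2)cc1` differs from compound 3 by 4-phenylphenyl in place of naphthalen-1-yl on an aromatic carbon. The readable step shows that swapping the group on that carbon can shift tolerated concentration at least modestly, yet with compound 3 already at a limit there is no room to see a rise. Compound 4 is therefore expected to stay high, with a step of an at least 1.3-fold lower number from compound 3 to compound 4 (0.12 log units; that floor lies within the scatter) expected to be small. The estimate for compound 4 is 200000 nM, between 60000 nM and 300000 nM.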

Compound 4, half-maximal cytotoxic concentration: > 253000 nM
Compound 4 was reported as a limit; the forecaster's own chance of this, stated with the estimate: 50%; middle value at least 1.2-fold (0.10 log units) away from the limit.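

Compound 4 gives only a limit in this assay, so a second group of two aromatic rings, 4-phenylphenyl, behaves at this carbon as naphthalen-1-yl does in compound 3. Replacing 3,5-dimethylphenyl with 4-phenylphenyl gives an at least 6.4-fold higher number from compound 2 to compound 4 (0.81 log units; beyond the scatter), which leaves compound 2 as the only compound shown with a measured number. The steps joining compound 4 to compound 1 and compound 3 cannot be read, as both ends of each are limits.

From the compounds shown here alone, how far these three compounds differ from one another stays open. So does the outcome in this assay with an amine or a carboxylic acid on this carbon.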